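The source may report more compounds than this note shows. Statements on the series, on what has been measured and on what is new or still open speak of the compounds shown alone.

Compound 1 `c1ccc(-c2ccc(-c3ccc(-c4nc5ccccc5[nH]4)cc3)cc2)cc1`: 32100 nM
Compound 2 `Oc1ccc(-c2ccc(-c3ccc(-c4nc5ccccc5[nH]4)cc3)cc2)cc1`: 36000 nM

In a functional assay on A2780 cells (Homo sapiens) for inhibition, read by sulforhodamine B assay (on this read-out higher numbers stand for weaker inhibition of growth and lower numbers for stronger inhibition of growth), compound 2 gives 36000 nM, which matches compound 1 within the scatter. Compound 3 `COc1ccc(-c2ccc(-c3ccc(-c4nc5ccccc5[nH]4)cc3)cc2)cc1` is derived from compound 2 by one change: methyl in place of hydrogen on an oxygen on an aromatic ring. This is methyl in place of hydrogen on an oxygen on an aromatic ring, turning hydroxy into methoxy. Going by the values given here, only one measured step bears on it: a 1.1-fold higher number from compound 1 to compound 2 (0.05 log units; within the scatter), for hydroxy in place of hydrogen on an aromatic carbon, and this stays within the scatter. Among the compounds with values here, that step is a different change, so it offers only indirect guidance, and no measured step shows the effect of the methyl itself. In this assay no shift beyond the scatter is therefore expected, in either direction. The expected change is a 1.1-fold lower number from compound 2 to compound 3 (0.05 log units; within the scatter). Compound 3 is estimated at 32000 nM, with an expected range of 14000 nM to 70000 nM.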

Compound 3, concentration for 50% growth inhibition: 100000 nM
Estimate against measurement, compound 3: 3.1-fold (0.49 log units) below; measured number outside the range, above it.
By their numbers in this assay, from the lowest: compounds 1 and 2 (each within the scatter of the next); then compound 3.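

Methyl in place of hydrogen on an oxygen on an aromatic ring is the first change in this series to move the result beyond the scatter: this assay gives a 2.8-fold higher number from compound 2 to compound 3 (0.44 log units; beyond the scatter), a modest loss of growth inhibition. Set against the unsubstituted compound, methoxy gives a 3.1-fold higher number from compound 1 to compound 3 (0.49 log units; beyond the scatter), whereas hydroxy gives only a 1.1-fold higher number from compound 1 to compound 2 (0.05 log units; within the scatter), so this end of the molecule is not indifferent to what it carries, and here the oxygen alone does not decide the result, since the weaker number comes only with the methyl on it. Nothing measured here accounts for this difference.

The compounds shown leave open whether a longer chain on the oxygen, such as ethoxy, would weaken inhibition further. They also leave open how an amine or a carboxylic acid would behave in place of the hydroxy.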